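Thiomorpholine to pyrrolidine on the thiosemicarbazide carbon

A few compounds are considered here, and "the series" means these few. Any claim that something is new, unique, unknown or untested is made for them only; others in the source may bear on it.

Of the compounds shown here, two have been measured. Compound 1 `Cc1ccnc(/C(N)=N/NC(=S)N2CCSCC2)c1` and compound 2 `N/C(=N\NC(=S)N1CCSCC1)c1ccccn1` share a core and differ only in that hydrogen stands in place of methyl on an aromatic carbon. In a functional assay on A-375 cells (Homo sapiens) for cytotoxicity, read by MTT assay, with a stated time of 72 h, tested at 10 uM (a higher number here means more inhibition of growth at the concentration tested, a lower number less inhibition of growth), compound 1 gives 74.5%, and compound 2 gives 83.9%. Compound 1 thus has the lower of the two numbers, but the step of a number 9.4 percentage points higher from compound 1 to compound 2 (within the scatter) is within the scatter, so the two compounds cannot be told apart on this basis.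

Compound 3 `Cc1ccnc(/C(N)=N/NC(=S)N2CCCC2)c1` has not been measured. Its change from compound 1 is pyrrolidin-1-yl in place of thiomorpholin-4-yl on a thiocarbonyl carbon. For the measured compounds named here, this change lies at a different place from the only measured step, which concerns the aromatic methyl, so no measured step bears directly on it. Going by the values given here, the single step available, from compound 1 to compound 2, was within the scatter, and nothing in the data points to a large effect of the ring change. The step of a number 0.5 percentage points lower from compound 1 to compound 3 (within the scatter) is therefore expected to be small, with no direction beyond the scatter. Compound 3 is estimated at 74%, in the range 55% to 90%.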

Compound 3, percent growth inhibition at one concentration: 86%
The estimate for compound 3 lay 12 percentage points below the measured number; the measured number falls inside the stated range.
By their numbers in this assay, from the lowest: compounds 1, 2 and 3 (each within the scatter of the next, the first and the last beyond it).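

In this assay, for the compounds shown here, pyrrolidin-1-yl in place of thiomorpholin-4-yl on a thiocarbonyl carbon gives a number 11.5 percentage points higher from compound 1 to compound 3 (beyond the scatter), the first step in this small set to lie beyond the scatter. Going by these compounds alone, the substituent on the thiocarbonyl carbon can therefore move the growth inhibition measurably, even if only modestly, whereas the one earlier step, with hydrogen in place of methyl on an aromatic carbon, showed a number 9.4 percentage points higher from compound 1 to compound 2 (within the scatter) and could not separate its two compounds. No measurement at hand explains why the pyrrolidin-1-yl compound gives the higher number.

The change replaces a six-membered non-aromatic ring with two hetero atoms by a five-membered one with a single hetero atom, so the compounds shown cannot say whether the size of the ring, the loss of the sulfur, or both together accompany the step. Piperidin-1-yl, a six-membered ring without sulfur, would separate these two changes, while morpholin-4-yl or an open dimethylamino group on the same thiocarbonyl carbon would show how far the result extends beyond these two rings.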